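This account rests on a few compounds, and the source may have more. Where it says the series, first, only, none or still open, it means among the compounds named here.

Working notes on the series.

Three compounds of the shared core have numbers in a functional assay on the whole organism (artery, strain albino) with Rattus norvegicus as the target, with a stated time of 720 min, at a dose of 10 mg/kg by the oral route; a lower number here means less inhibition, a higher number more inhibition at the dose given (going by the name of the read-out). Compound 1 `COc1ccc(C2N=C(SCc3ccccc3Cl)NC(C)=C2C(=O)Nc2ccc(F)cc2)cc1OC` gives 23.2%. Compound 2 `COc1ccc(C2N=C(SCc3ccc(Cl)cc3)NC(C)=C2C(=O)Nc2ccc(F)cc2)cc1OC` gives 22.2%. Compound 3 `CC1=C(C(=O)Nc2ccc(F)cc2)C(c2ccc([N+](=O)[O-])cc2)N=C(SCc2ccccc2Cl)N1` gives 13.9%. On the numbers alone compound 3 sits at the bottom of the three, but its gap to compound 2 and its gap to compound 1 are both within the scatter, so the three are not separated by this assay.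

Two single-point steps are known. The step of a number 1 percentage points lower from compound 1 to compound 2 (within the scatter) changes only the aryl on the saturated chain carbon bound to a sulfur. The step of a number 9.3 percentage points lower from compound 1 to compound 3 (within the scatter) changes only the aryl on the saturated ring carbon.

Compound 4 `CC1=C(C(=O)Nc2ccc(F)cc2)C(c2ccc([N+](=O)[O-])cc2)N=C(SCc2ccc(F)cc2)N1` differs from compound 3 by 4-fluorophenyl in place of 2-chlorophenyl on a saturated chain carbon bound to a sulfur. Among the measured compounds shown here, the step that bears on it is the one from compound 1 to compound 2, which also altered the aryl on the saturated chain carbon bound to a sulfur and stayed within the scatter. For the measured compounds named here, there is no measured step for a fluorine in that position. On this basis no step beyond the scatter is expected in this assay, in either direction, and compound 4 is expected at 14%, between 4% and 26%, meaning an expected step of a number 0.1 percentage points higher from compound 3 to compound 4 (within the scatter).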

Compound 4, a percentage reported as inhibition, in the whole organism at one dose (the size of the read-out at that dose, not a potency): 19.6%
Compound 4: the middle estimate sits 5.6 percentage points below what was measured; the range from low to high includes it.
By their numbers in this assay, from the lowest: compounds 3, 4, 2 and 1 (each within the scatter of the next).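

In this assay the step of a number 5.7 percentage points higher from compound 3 to compound 4 (within the scatter) extends what the step of a number 1 percentage points lower from compound 1 to compound 2 (within the scatter) showed: the aryl on the saturated chain carbon bound to a sulfur has now been exchanged with 4-nitrophenyl on the saturated ring carbon as well as with 3,4-dimethoxyphenyl there, and neither exchange leaves the scatter. This new step swaps the halogen as well as where it sits on the ring, 2-chlorophenyl giving way to 4-fluorophenyl, so the two parts of the change cannot be told apart from this one pair, and within the scatter neither can be said to move the read-out. No measurement shown here offers an explanation of these numbers or of any difference between them.

Still open is whether any change at this place can reach beyond the scatter, since the groups shown there are all halogen-bearing phenyl rings on the same benzyl link, and a basic amine, a carboxylic acid or a longer chain in place of the aryl would test that more severely. Also open, from the compounds shown here alone, is how 4-chlorophenyl and 4-fluorophenyl compare on one unchanged core, which would separate the kind of halogen from its place on the ring.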